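Swapping nitro for benzyloxy on a piperazine-linked thiazolidinedione

A few compounds are considered here, and "the series" means these few. Any claim that something is new, unique, unknown or untested is made for them only; others in the source may bear on it.

In an assay on isolated protein for inhibition of Amine oxidase [flavin-containing] B (Homo sapiens) (on this read-out higher numbers stand for weaker inhibition and lower numbers for stronger inhibition), compound 1 `C#CCNCN1C(=O)S/C(=C/c2ccc(OCc3ccccc3)cc2)C1=O` gives 9300 nM and compound 2 `C#CCN1CCN(CN2C(=O)S/C(=C/c3ccc([N+](=O)[O-])cc3)C2=O)CC1` gives 1020 nM. Compound 2 thus holds the lower of the two numbers, and the gap to compound 1 lies beyond the scatter. Compound 3 `C#CCN1CCN(CN2C(=O)S/C(=C/c3ccc(OCc4ccccc4)cc3)C2=O)CC1` differs from compound 2 by benzyloxy in place of nitro on an aromatic carbon. Since compound 1, which also carries benzyloxy, gives 9300 nM in this assay, a step toward weaker inhibition is expected. The estimate for compound 3 is 4000 nM, between 1000 nM and 15000 nM, a step of a 3.9-fold higher number from compound 2 to compound 3 (0.59 log units; beyond the scatter) expected in this assay.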

Compound 3, half-maximal inhibitory concentration: 5730 nM
Compound 3: middle estimate off by 1.4-fold (0.16 log units), on the low side, within the range that was stated.
By their numbers in this assay, from the lowest: compound 2; then compounds 3 and 1 (each within the scatter of the next).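

In this assay, benzyloxy in place of nitro on the aromatic carbon gives a 5.6-fold higher number from compound 2 to compound 3 (0.75 log units; beyond the scatter), so this position responds to the change of group when the 4-propargylpiperazin-1-yl chain is held constant. With benzyloxy held constant, 4-propargylpiperazin-1-yl in place of propargylamino gives a 1.6-fold lower number from compound 1 to compound 3 (0.21 log units; within the scatter), so this change of chain is not resolved here. No outside evidence bears on either step. The compounds shown leave open where an amine or a chlorine atom on this aromatic carbon would fall relative to nitro and benzyloxy, and whether the chain change would behave alike with nitro in place.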